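Methyl additions on a series held at the assay limit

The source may hold more compounds than are shown below. What is called first, only, known or untested is meant among the compounds shown, and "the series" means these compounds.

Measured compounds
- compound 1 `O=C1CN(C2CCCC2)c2nc(Nc3ccc(N4CCCCC4)cn3)ncc2N1`: > 30000 nM
- compound 2 `CC1CCN(c2ccc(Nc3ncc4c(n3)N(C3CCCC3)CC(=O)N4)nc2)CC1`: > 30000 nM
- compound 3 `CN1C(=O)CN(C2CCCC2)c2nc(Nc3ccc(N4CCCCC4)cn3)ncc21`: > 30000 nM

All three measured compounds share one core, carrying a cyclopentyl group on the fused ring system and an arylamine bearing a piperidin-1-yl group. In a functional assay on HeLa cells (Homo sapiens) for inhibition, read by MTT assay, with a stated time of 48 h (a higher number here means a weaker inhibitor, a lower number a stronger inhibitor), compound 1 gives > 30000 nM, which is a limit of the assay and not a number. Compound 2 differs from compound 1 by methyl in place of hydrogen on a saturated ring carbon. In this assay compound 2 gives > 30000 nM, again a limit. Compound 3 differs from compound 1 by methyl in place of hydrogen on an amide-type nitrogen in a ring. In this assay compound 3 gives > 30000 nM, a limit as well. The step that the two limits leave unreadable from compound 1 to compound 2 and the step that the two limits leave unreadable from compound 1 to compound 3 cannot be sized because of the limit of > 30000 nM in this assay, at which 3 of the 3 values shown sit.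

Compound 4 `CC1CCN(c2ccc(Nc3ncc4c(n3)N(C3CCCC3)CC(=O)N4C)nc2)CC1` has not yet been measured. It differs from compound 3 by methyl in place of hydrogen on a saturated ring carbon. This is the same change as that from compound 1 to compound 2: the two place descriptions read alike word for word, piperidin-1-yl to 4-methylpiperidin-1-yl in both cases. That earlier change ran from one limit to another and left nothing readable. Compound 4 is expected to show a step of a number no higher from compound 3 to compound 4 (the limit leaves the size open) in this assay. This expectation rests on compound 2, which after the same change gives > 30000 nM, a limit. Compound 4 is therefore estimated at about 30000 nM in this assay, most likely reported only as a limit.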

Compound 4, half-maximal inhibitory concentration: > 30000 nM
Compound 4: a limit, no number; the forecaster's own chance of this, stated with the estimate: 85%; the middle value sits exactly at the limit.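

In this assay compound 4 gives > 30000 nM, a limit of the assay and not a number. No new step can be read from compound 3 to compound 4 or from compound 2 to compound 4, because each pair has a limit at both ends: the limit of > 30000 nM in this assay, at which 4 of the 4 values shown sit. The compounds shown leave open what size either methyl addition has in this assay, and whether any compound of this series gives a readable value there.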